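This account rests on a few compounds, and the source may have more. Where it says the series, first, only, none or still open, it means among the compounds named here.

Compound 1 `CCN(CC)c1ccc2cc(C(=O)c3ccc(N4CCN(C(=O)CN5CCN(C(=O)CCl)CC5)CC4)cc3)oc2c1` and compound 2 `CCN(CC)c1ccc2cc(C(=O)c3ccc(N4CCN(C(=O)CN5CCN(Cc6ccc(C#N)cc6)CC5)CC4)cc3)oc2c1` share one core and differ only at an amine nitrogen in a ring. In a functional assay on MCF7 cells (Homo sapiens) for cytotoxicity, read by MTT assay, with a stated time of 48 h (on this read-out higher numbers stand for weaker inhibition and lower numbers for stronger inhibition), compound 1 gives only a limit, > 40000 nM. Compound 2 likewise gives only a limit in this assay, > 40000 nM. The step that the two limits leave unreadable from compound 1 to compound 2 therefore cannot be sized, given (the limit of > 40000 nM in this assay, at which 2 of the 2 values shown sit). Compound 3 `CCOC(=O)CN1CCN(CC(=O)N2CCN(c3ccc(C(=O)c4cc5ccc(N(CC)CC)cc5o4)cc3)CC2)CC1` differs from compound 2 by ethoxycarbonyl in place of 4-cyanophenyl on a saturated chain carbon bound to an amine nitrogen in a ring. For the measured compounds named here, no measured step bears on such a change, and the two limits give no direction. Compound 3 is expected to remain at the limit, the step that the limit leaves unreadable from compound 2 to compound 3 being estimated as none beyond the scatter. The estimate for compound 3 is 50000 nM, ranging from 15000 nM to 200000 nM.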

Compound 3, half-maximal inhibitory concentration: > 40000 nM
Compound 3 gave a limit, no number (the forecaster's own chance of this, stated with the estimate: 85%); the middle value lies beyond the limit too.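

No step can be read among compound 1, compound 2 and compound 3 in this assay: the limit of > 40000 nM in this assay, at which 3 of the 3 values shown sit.

As far as these compounds go, whether any group on this amine nitrogen in a ring gives a measurable value in this assay remains open.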